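Replacing the Ester Group of Compound 1

The source may hold more compounds than are shown below. What is called first, only, known or untested is meant among the compounds shown, and "the series" means these compounds.

Going by the values given here, compound 1 (`NCc1ccc(C(=O)Nc2ccncc2F)cc1-c1cccc(C(=O)OCC2CC2)c1`) gives 0.3 h in an ADME assay on a cell-free system (plasma, Homo sapiens) for metabolic stability, read by LC-MS (a lower number here means that the compound disappears faster, a higher number that the compound lasts longer), and holds the lower of the two numbers measured so far. In this assay compound 2 (`CCOC(=O)c1cccc(-c2cc(C(=O)Nc3ccncc3)ccc2CN)c1`) gives 0.683 h as the higher number, and the gap between them lies beyond the usual scatter of repeats. These two compounds differ in more than one place, so their gap cannot be tied to any single change.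

Compound 3 (`NCc1ccc(C(=O)Nc2ccncc2F)cc1-c1cccc(C(=O)OC2CCCOC2)c1`) keeps the core of compound 1 and carries oxan-3-yl in place of cyclopropylmethyl on an oxygen next to a carbonyl group. Among the compounds with values here, no measured step covers this change, so the expectation is a loose one. It rests on compound 1 sitting at the low end with 0.3 h so far, while compound 2 reaches 0.683 h in the same series. The expected move is a 2.3-fold higher number from compound 1 to compound 3 (0.37 log units; beyond the scatter) towards a longer half-life, a modest estimated rise that may barely clear the scatter. The half-life of compound 3 in this assay is estimated at 0.7 h (range 0.3 h to 2 h).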

Compound 3, half-life: 0.3 h
Estimate against measurement, compound 3: 2.3-fold (0.37 log units) above; low and high end bracket the measured number.
By their numbers in this assay, from the lowest: compounds 1 and 3 (each within the scatter of the next); then compound 2.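

In this assay, putting oxan-3-yl in place of cyclopropylmethyl on an oxygen next to a carbonyl group gives no change at the digits printed from compound 1 to compound 3 (within the scatter), and this is the only step shown that isolates a single place. It shows that, on the core of compound 1, the half-life stays put when a three-membered ring of carbon only gives way to a six-membered ring with one hetero atom, a group with more heavy atoms and one hydrogen-bond acceptor. Nothing available here accounts for this outcome, so the result stands without an explanation.

As far as these compounds go, both groups in this step carry a ring and no net charge, so it remains open how a longer open chain or a group bearing an amine would behave on this oxygen. Also open, from the compounds shown here alone, is whether an amide in place of the ester linkage would shift the half-life on the core of compound 1, since this step changes only the group on the oxygen and leaves the carbonyl and that oxygen in place.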